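The source may hold more compounds than are shown below. What is called first, only, known or untested is meant among the compounds shown, and "the series" means these compounds.

Series notes, step from compound 2 to compound 3.

Compound 1 `CN(CC1CCC/C(=C\c2ccccc2)C1=O)c1ccccc1` gives 76.6% in a functional assay on the whole organism (strain Wistar) for inhibition, with Rattus norvegicus as the target, read by paw edema, with stated times of 1 h and 3 h, at a dose of 200 mg/kg by the oral route; on this read-out higher numbers stand for more inhibition at the one dose given (going by the name of the read-out) and lower numbers for less inhibition. Among the measured compounds shown here, compound 2 `Cc1ccc(N(C)CC2CCC/C(=C\c3ccccc3)C2=O)cc1`, which carries a methyl in place of hydrogen on an aromatic carbon, gives 25.5% in this assay; this is the lowest of the two numbers so far, and the step of a number 51.1 percentage points lower from compound 1 to compound 2 (beyond the scatter) lies beyond the scatter. The next member, compound 3 `Cc1cccc(N(C)CC2CCC/C(=C\c3ccccc3)C2=O)c1`, is not yet measured in this assay. It differs from compound 2 by 3-methylphenyl in place of 4-methylphenyl on an amine nitrogen, so the same atoms are joined differently and only the position of the methyl on the aromatic ring is changed.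

For the measured compounds named here, the one measured step, a number 51.1 percentage points lower from compound 1 to compound 2 (beyond the scatter), concerns the presence of the methyl, not its position, so it bears on the new step only indirectly: it shows that a methyl on this ring can move the read-out by a large amount, but gives no sign of which way a shift of the methyl would go. The step of a number 14.5 percentage points higher from compound 2 to compound 3 (beyond the scatter) is therefore expected to be modest and of uncertain direction, with a wide range. Compound 3 is estimated at 40%, between 15% and 70%.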

Compound 3, a percentage reported as inhibition, in the whole organism at one dose (the size of the read-out at that dose, not a potency): 46.8%
The estimate for compound 3 lay 6.8 percentage points below the measured number; the measured number falls inside the stated range.
By their numbers in this assay, from the lowest: compound 2; then compound 3; then compound 1.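

In this assay the shift of the methyl alone, 3-methylphenyl in place of 4-methylphenyl on an amine nitrogen, gives a number 21.3 percentage points higher from compound 2 to compound 3 (beyond the scatter) and so shows that the read-out depends on where the methyl sits on this ring, not only on whether a methyl is present. The 3-methylphenyl compound still falls short of the unsubstituted phenyl, with a number 29.8 percentage points lower from compound 1 to compound 3 (beyond the scatter) on the same read-out, so both methyl compounds stand lower than compound 1, while the drop on adding a methyl is smaller for the 3-methylphenyl than for the 4-methylphenyl. Nothing at hand explains why the two placements of the methyl differ.

Going by these compounds, whether a methoxy group or a chlorine on the same ring would follow the same order of placements as the methyl remains open, and so does whether a longer chain such as ethyl would take the read-out further down than methyl does. The compounds shown also leave open whether any substituent on this ring can match or pass compound 1 at the single dose used.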